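The source may hold more compounds than are shown below. What is called first, only, known or untested is meant among the compounds shown, and "the series" means these compounds.

Compound 1 `Nc1nc(=O)n(C2OC(CO)C(I)C2O)cc1F` is the starting point here. In a functional assay on L5178Y cells (Mus musculus) for antiproliferative activity (on this read-out higher numbers stand for weaker inhibition and lower numbers for stronger inhibition), compound 1 gives 10 ug/mL, and this is the only plain number among the two results shown. The other result belongs to compound 2 `Cc1ccc(S(=O)(=O)O[C@@H]2[C@@H](O)[C@H](n3ccc(N)nc3=O)O[C@@H]2CO)cc1`. In this assay compound 2 gives > 100 ug/mL, which is a limit of the assay rather than a number, and the limit of > 100 ug/mL in this assay, at which 1 of the 2 values shown sits, describes it as such. Among the compounds with values here, no step between two measured compounds is available, so the size of any change has to be guessed rather than read off.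

Compound 3 `Nc1nc(=O)n(C2OC(CO)C(Cl)C2O)cc1F` differs from compound 1 in a single place: chloro in place of iodo on a saturated ring carbon. A change of this kind, one halogen for another on the saturated ring, is expected to shift this assay by only a modest amount, with weaker inhibition somewhat more likely than stronger. The expected step from compound 1 to compound 3 is a 2.0-fold higher number from compound 1 to compound 3 (0.30 log units; within the scatter). Compound 3 is therefore estimated at 20 ug/mL, with a range from 4 ug/mL to 100 ug/mL.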

Compound 3, concentration for 50% inhibition: 71 ug/mL
Compound 3: middle estimate off by 3.6-fold (0.55 log units), on the low side; measured number inside the range.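

Swapping iodo for chloro on this saturated ring carbon gives a 7.1-fold higher number from compound 1 to compound 3 (0.85 log units; beyond the scatter) in this assay. Within the data shown here, this is the first step that can be read in this set, and it shows that the assay responds to which halogen sits at this place, even though one heavy atom simply replaces another and the counts of donors and acceptors stay the same. Of these two halogens, iodo goes with the stronger inhibition, and nothing measured here bears on the reason for this difference.

With only two halogens compared, the compounds shown leave open where a bromo group would fall relative to iodo and chloro. They also leave open whether a group that is not a halogen, such as an amine or a methyl group, could match or improve on iodo at this place.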